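Methyl added to the dimethoxyphenyl ring: clearance notes

A few compounds are considered here, and "the series" means these few. Any claim that something is new, unique, unknown or untested is made for them only; others in the source may bear on it.

Measured so far in an in vitro ADME assay on microsomes from liver (Homo sapiens) for metabolic stability, with a stated time of 15 min; a lower number here means slower removal, a higher number faster removal of the compound:
compound 1, `CCc1nn2c(-c3c(OC)cccc3OC)cccc2c1N(CC1CCOCC1)CC1CC1`, gives 740 mL.min-1.g-1
compound 2, `COCc1cc(OC)c(-c2cccc3c(N(CC4CCOCC4)CC4CC4)c(OC)nn23)c(OC)c1`, gives 760 mL.min-1.g-1
compound 3, `CCCN(CC1CCOCC1)c1c(CC)nn2c(-c3c(OC)cc(COC)cc3OC)cccc12`, gives 700 mL.min-1.g-1

All three numbers lie within the usual scatter of one another, so compound 1 stands in a tight cluster with compound 2 and compound 3, and none can be set apart from the others.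

Compound 4, `CCc1nn2c(-c3c(OC)cc(C)cc3OC)cccc2c1N(CC1CCOCC1)CC1CC1`, is not yet measured. It differs from compound 1 by methyl in place of hydrogen on an aromatic carbon. Among the compounds with values here, no pair of measured compounds shows this change, so there is no step to lean on. The expectation is that the step from compound 1 to compound 4 stays within the scatter, a 1.1-fold higher number from compound 1 to compound 4 (0.03 log units; within the scatter). Compound 4 is estimated at 800 mL.min-1.g-1, in the range 450 mL.min-1.g-1 to 1400 mL.min-1.g-1.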

Compound 4, intrinsic clearance in microsomes: 440 mL.min-1.g-1
Beside the measured number, compound 4's estimate is 1.8-fold (0.26 log units) above it; measured number outside the range, below it.
By their numbers in this assay, from the lowest: compounds 4, 3, 1 and 2 (each within the scatter of the next).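

The series now has a single-place step on this ring: in this assay, methyl in place of hydrogen gives a 1.7-fold lower number from compound 1 to compound 4 (0.23 log units; within the scatter) and does not leave the usual scatter. This position, para to a large group, therefore takes a methyl without a shift that can be told apart from repeat-measurement noise. No measured data bear on the reason for this step.

From the compounds shown here alone, whether an amine, a carboxylic acid or a longer chain at this position would give a step beyond the scatter remains open. Also open, going by these compounds, is whether methyl here gives a similar step with other groups on the shared core.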